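From hydroxymethyl to iodo on the aniline ring

The compounds below may be only part of what the source reports. "The series", "measured", "known", "first", "only" and "open" are said of these compounds alone.

Compound 1 `C#CCN(Cc1ccc2nc(C)nc(O)c2c1)c1ccccc1`: > 6500 nM (a limit)
Compound 2 `C#CCN(Cc1ccc2nc(C)nc(O)c2c1)c1cccc(CO)c1`: 48000 nM

Among the measured compounds shown here, in a functional assay on L1210 cells (Mus musculus) for inhibition (a lower number here means a stronger inhibitor, a higher number a weaker inhibitor), compound 2 gives 48000 nM, the only actual number available for this series. Compound 1 gives > 6500 nM, which is a limit and not a number.

Compound 3 `C#CCN(Cc1ccc2nc(C)nc(O)c2c1)c1cccc(I)c1`, not yet measured, differs from compound 2 at a single place: iodo in place of hydroxymethyl on an aromatic carbon. This is iodo in place of hydroxymethyl on an aromatic carbon, so 3-(hydroxymethyl)phenyl becomes 3-iodophenyl.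

For the measured compounds named here, the one measured step that touches this position is a step that the limit leaves unreadable from compound 1 to compound 2. It rests on (the limit of > 6500 nM in this assay, at which 1 of the 2 values shown sits), so it offers no size to carry over, and the direction of the coming step cannot be read from the data. The value of compound 2 at 48000 nM remains the sole anchor, so the expectation stays close to it, with a modest lean toward stronger inhibition. The expected change is a 2.4-fold lower number from compound 2 to compound 3 (0.38 log units; beyond the scatter), and this estimate is uncertain. The estimate for compound 3 is 20000 nM, with an expected range from 4000 nM to 70000 nM.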

Compound 3, half-maximal inhibitory concentration: > 5300 nM
Compound 3: no number, only a limit (the forecaster's own chance of this, stated with the estimate: 25%); the middle value lies beyond the limit too.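

In this assay compound 3 gives > 5300 nM, which is a limit and not a number. The steps to compound 3 from compound 1 and from compound 2 cannot be read. The compounds shown leave open whether iodo, hydroxymethyl or hydrogen at this place gives the stronger inhibitor, and by how much.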